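Compound 3 loses its pyrrolidin-1-yl group

A few compounds are considered here, and "the series" means these few. Any claim that something is new, unique, unknown or untested is made for them only; others in the source may bear on it.

Compound 1 `Cc1nc(C)n(CC(=O)N2CCN(c3sc(C(F)(F)F)nc3-c3cnc(OC(C)C)nc3)C[C@H]2C)n1` gives 16 mL.min-1.g-1
Compound 2 `Cc1nc(C)n(CC(=O)N2CCN(c3sc(C(F)(F)F)nc3-c3cnc(C4CC4)nc3)C[C@H]2C)n1` gives < 10 mL.min-1.g-1 (a limit of the assay, not a number)
Compound 3 `Cc1nc(C)n(CC(=O)N2CCN(c3sc(C(F)(F)F)nc3-c3cnc(N4CCCC4)nc3)C[C@H]2C)n1` gives 338 mL.min-1.g-1

In a toxicity assay on microsomes from liver (Homo sapiens) for metabolic stability, read by LC-MS, using NADPH, tested at 1 uM (a lower number here means slower removal, a higher number faster removal of the compound), compound 3 has the highest number of the three. Compound 4 `Cc1nc(C)n(CC(=O)N2CCN(c3sc(C(F)(F)F)nc3-c3ccc(C(F)(F)F)nc3)C[C@H]2C)n1` is still unmeasured, and it differs from compound 3 as follows: 6-(trifluoromethyl)pyridin-3-yl in place of 2-(pyrrolidin-1-yl)pyrimidin-5-yl on an aromatic carbon. Going by the values given here, no measured step makes this exact swap. The closest steps bring pyrrolidin-1-yl in, and both are large and beyond the scatter: a 21-fold higher number from compound 1 to compound 3 (1.32 log units; beyond the scatter) and an at least 33-fold higher number from compound 2 to compound 3 (1.52 log units; beyond the scatter). The second of these rests on a limit. Between the two groups without pyrrolidin-1-yl, the floor of the step stays within the scatter: an at least 1.6-fold lower number from compound 1 to compound 2 (0.20 log units; that floor lies within the scatter). Compound 4 also lacks pyrrolidin-1-yl, so a large fall is expected in this assay. The expected step is a 24-fold lower number from compound 3 to compound 4 (1.38 log units; beyond the scatter). Compound 4 is estimated at 14 mL.min-1.g-1, with an expected range from 6 mL.min-1.g-1 to 40 mL.min-1.g-1.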

Compound 4, intrinsic clearance in microsomes: < 10 mL.min-1.g-1
Compound 4: no number, only a limit; the forecaster's own chance of this, stated with the estimate: 35%; at least 1.4-fold (0.14 log units) between middle value and limit.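

In this assay, going by these compounds alone, replacing the whole 2-(pyrrolidin-1-yl)pyrimidin-5-yl with 6-(trifluoromethyl)pyridin-3-yl brings an at least 33-fold lower number from compound 3 to compound 4 (1.52 log units; beyond the scatter), so slow removal at this position does not depend on keeping the pyrimidine ring, the only ring the earlier compounds carried here. The groups without pyrrolidin-1-yl remain unseparated, with an at least 1.6-fold lower number from compound 1 to compound 4 (0.20 log units; that floor lies within the scatter). The reading for compound 4 is a limit, not a number, and the step from compound 2 to compound 4 cannot be read because both readings are limits: the limit of < 10 mL.min-1.g-1 in this assay, at which 2 of the 4 values shown sit.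

Still open, going by these compounds, is whether pyrrolidin-1-yl on the pyridine ring would also bring fast removal. Also open, on these data alone, is how an open-chain amine such as dimethylamino would behave on the pyrimidine ring.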